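The compounds below may be only part of what the source reports. "The series", "measured", "known", "first", "only" and "open" are said of these compounds alone.

Series notes. Compound 1 `CCC(C)C(NC(=O)NO)C(=O)NC1CCCCC1` in a functional assay on CCRF-CEM cells (Homo sapiens) for inhibition (a lower number here means a stronger inhibitor, a higher number a weaker inhibitor), gives 153000 nM. Compound 2 `CC(C)C(NC(=O)NO)C(=O)NC1CCCC1` returns only a limit of this assay, > 200000 nM, not a number. Compound 2 therefore sits at the limit of > 200000 nM in this assay, at which 1 of the 2 values shown sits. Compound 3 `CCC(C)C(NC(=O)NO)C(=O)NC1CCCC1` carries methyl in place of hydrogen on a saturated chain carbon, three bonds along the chain from an amide-type nitrogen and a carbonyl carbon, that is, methyl in place of hydrogen on a saturated chain carbon, three bonds along the chain from an amide-type nitrogen and a carbonyl carbon. Going by the values given here, no step between measured compounds is available; the step is expected to be small, toward stronger inhibition, if it exceeds the scatter at all. Compound 3 is expected at 180000 nM, in the range 90000 nM to 400000 nM, a step of an at least 1.1-fold lower number from compound 2 to compound 3 (0.04 log units; that floor lies within the scatter).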

Compound 3, half-maximal inhibitory concentration: > 100000 nM
Compound 3: only a limit was reported; the forecaster's own chance of this, stated with the estimate: 50%; the middle value lies beyond the limit too.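

Compound 3 returns only a limit in this assay, > 100000 nM, so its steps from compound 2 and from compound 1 cannot be read. The compounds shown leave open whether methyl in place of hydrogen, or cyclopentyl in place of cyclohexyl, changes inhibition at all.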